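The source may report more compounds than this note shows. Statements on the series, on what has been measured and on what is new or still open speak of the compounds shown alone.

Measured compounds:
compound 1, `c1ccc(-c2nnn[nH]2)c(-c2ccc(CCc3nc(CC4CCCC4)c[nH]3)cc2)c1`: in a functional assay for agonist activity at Bombesin receptor subtype-3 (Mus musculus) (a lower number here means that less compound is needed, a higher number that more compound is needed for the effect), compound 1 gives 16 nM.
compound 2, `CCC(C)(C)Cc1c[nH]c(CCc2ccc(-c3ccccc3OCC(=O)O)cc2)n1`: in this assay compound 2 gives "not determined" (no result reported).

Compound 2 thus has no place on the numbers shown; the only measured value in the set belongs to compound 1. Compound 3, `CCC(C)(C)Cc1c[nH]c(CCc2ccc(-c3ccccc3OCc3nc(C(F)(F)F)n[nH]3)cc2)n1`, differs from compound 2 in a single spot: 3-(trifluoromethyl)-1H-1,2,4-triazol-5-yl in place of carboxy on a saturated chain carbon bound to an oxygen on an aromatic ring. Among the compounds with values here, with no value for compound 2, no measured step joins the two, and neither the size nor the direction of the change in this assay can be read from the data; any expectation must lean on the single number given for compound 1. Taking that as the only anchor, compound 3 is expected to land near 30 nM, with an estimated range from 5 nM to 200 nM, a deliberately wide span given how little is known.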

Compound 3, half-maximal effective concentration: 12 nM
Compound 3: middle estimate off by 2.5-fold (0.40 log units), on the high side; the range from low to high includes it.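

Within the data shown here, compound 2 has no number in this assay, so no step to compound 3, at 12 nM, can be read. What replacing carboxy with 3-(trifluoromethyl)-1H-1,2,4-triazol-5-yl does to the value stays open, and nothing shown offers an explanation of this result.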